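From 4-methoxyphenyl to thiophen-2-yl on a carbonyl carbon

The source may report more compounds than this note shows. Statements on the series, on what has been measured and on what is new or still open speak of the compounds shown alone.

Of the compounds shown here, three built on a shared core have been measured so far: compound 1 (`C=C(Br)C(=O)Nc1ccc(/C=C/C(=O)c2ccc(Cl)cc2)cc1`), compound 2 (`C=C(Br)C(=O)Nc1ccc(/C=C/C(=O)c2ccc(Cl)c(Cl)c2)cc1`) and compound 3 (`C=C(Br)C(=O)Nc1ccc(/C=C/C(=O)c2ccc(OC)cc2)cc1`). In a functional assay on HeLa cells (Homo sapiens) for antiproliferative activity, with a stated time of 48 h (on this read-out higher numbers stand for weaker inhibition and lower numbers for stronger inhibition), compound 1 gives 1600 nM, compound 2 gives 3200 nM and compound 3 gives 1400 nM. Compound 3 therefore stands level with compound 1, and only compound 2 is separated from it.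

The next compound, compound 4 (`C=C(Br)C(=O)Nc1ccc(/C=C/C(=O)c2cccs2)cc1`), has thiophen-2-yl in place of 4-methoxyphenyl on a carbonyl carbon.

All three measured steps concern this same aromatic group. Adding a chloro group gives a 2.0-fold higher number from compound 1 to compound 2 (0.30 log units; within the scatter), and methoxy in place of chloro gives a 1.1-fold lower number from compound 1 to compound 3 (0.06 log units; within the scatter). The closest parallel, a whole-group exchange at the same carbonyl carbon, gives a 2.3-fold lower number from compound 2 to compound 3 (0.36 log units; beyond the scatter). Among the compounds with values here, no measured compound carries a five-membered aromatic ring, so the data offer no direct guide to thiophen-2-yl. With the largest step here only modest, the expected change is a 1.4-fold higher number from compound 3 to compound 4 (0.13 log units; within the scatter), and no confident shift beyond the scatter is anticipated. For compound 4 the estimated value is 1900 nM, with an expected range from 750 nM to 4800 nM.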

Compound 4, half-maximal inhibitory concentration: 340 nM
For compound 4 the middle estimate is 5.6-fold (0.75 log units) above the measured one; measured number outside the range, below it.
By their numbers in this assay, from the lowest: compound 4; then compounds 3, 1 and 2 (each within the scatter of the next, the first and the last beyond it).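

In this assay the ring itself proves to matter at this carbonyl carbon: thiophen-2-yl in place of 4-methoxyphenyl gives a 4.1-fold lower number from compound 3 to compound 4 (0.61 log units; beyond the scatter), and the same exchange against the chlorinated rings gives a 4.7-fold lower number from compound 1 to compound 4 (0.67 log units; beyond the scatter) and a 9.4-fold lower number from compound 2 to compound 4 (0.97 log units; beyond the scatter). The earlier compounds shown here varied only the groups carried on a six-membered aromatic ring of carbon, whereas replacing that ring with a five-membered aromatic ring containing sulfur produces a larger step than any seen among them and makes compound 4 the most potent of the four, with all of its steps beyond the scatter. Nothing shown here establishes what underlies this gain in antiproliferative activity.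

This exchange alters ring size, ring atoms and the substituents all at once, so a plain phenyl ring and a furan-2-yl ring, with oxygen where thiophen-2-yl has sulfur, would be needed to begin separating these changes. On these data alone, it also remains open whether the attachment point on the ring matters, as thiophen-3-yl would show, and whether a chloro or methoxy group on the thiophene ring would preserve the gain.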